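Flipping one double bond in compound 3

The compounds below may be only part of what the source reports. "The series", "measured", "known", "first", "only" and "open" are said of these compounds alone.

Measured so far in a functional assay on SK-MEL-2 cells (Homo sapiens) for cytotoxicity; on this read-out lower numbers stand for an effect already at smaller amounts and higher numbers for an effect only at larger amounts of compound:
- compound 1, `CC1=C(O)[C@@H](C/C(C)=C\CCC(C)/C=C/C=C(\C)CCCc2ccoc2)OC1=O`: compound 1 reaches only the limit > 30 ug/mL, which is a limit of this assay rather than a number.
- compound 2, `CC1=C(O)[C@H](C/C(C)=C\CCC(C)/C=C\C=C(\C)CCCc2ccoc2)OC1=O`: compound 2 gives 7.78 ug/mL.
- compound 3, `CC1=C(O)/C(=C\[C@H](C)CCC/C(C)=C/CCc2coc(Cc3ccoc3)c2)OC1=O`: compound 3 gives 10.2 ug/mL.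

Among the two numbers, compound 3 holds the highest one; its nearest neighbour is compound 2, and the gap between them lies within the scatter. The third value is a limit (the limit of > 30 ug/mL in this assay, at which 1 of the 3 values shown sits), so it cannot be ranked.

Compound 4, `CC1=C(O)/C(=C/[C@H](C)CCC/C(C)=C/CCc2coc(Cc3ccoc3)c2)OC1=O`, is not yet measured. It differs from compound 3 only in the drawn geometry of one double bond: the two compounds have the same atoms and bonds and differ only in configuration as drawn: 1 of 3 stereo elements differ; a double bond is drawn E in compound 3 and Z in compound 4.

Within the data shown here, only one measured step touches geometry: an at least 3.8-fold lower number from compound 1 to compound 2 (0.58 log units; beyond the scatter). That step, though, changes three stereo elements at once, and one of the two (the fact that one of compounds 1 and 2 is drawn with a defined configuration and the other without, at the place where they differ), so the share of a single double-bond flip cannot be read from it. It shows that geometry can matter, not how much or in which direction here.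

The step from compound 3 to compound 4 is therefore expected to be small or uncertain in direction, a 1.0-fold lower number from compound 3 to compound 4 (0.01 log units; within the scatter). For compound 4 an estimate of 10 ug/mL is made, within 3 ug/mL to 30 ug/mL.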

Compound 4, concentration for half-maximal effect: 8.95 ug/mL
Compound 4: middle estimate off by 1.1-fold (0.05 log units), on the high side; the measured number falls inside the stated range.
By their numbers in this assay, from the lowest: compounds 2, 4 and 3 (each within the scatter of the next). At a limit, above all of these: compound 1.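

In this assay, the geometry of this one double bond gives a 1.1-fold lower number from compound 3 to compound 4 (0.06 log units; within the scatter), so the E and Z forms drawn here cannot be told apart on this read-out. The earlier geometry step, an at least 3.8-fold lower number from compound 1 to compound 2 (0.58 log units; beyond the scatter), changes three stereo elements at once and so cannot be traced to any one of them, whereas this pair isolates a single double bond and nothing else: the fact that compounds 3 and 4 differ only in the configuration as drawn. The result therefore concerns this double bond alone and does not mean that geometry is unimportant elsewhere in the series, since the step between compound 1 and compound 2 still lies beyond the scatter.

The compounds shown leave open which of the three stereo elements that differ between compound 1 and compound 2 accounts for that step, as neither the stereocentre nor either double bond is changed there on its own. They also leave open how this read-out would respond to a carboxylic acid or an amine on these structures, and whether compound 3 and compound 4 would still match with such a group in place.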